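This account rests on a few compounds, and the source may have more. Where it says the series, first, only, none or still open, it means among the compounds named here.

Compound 1 `FC(F)(F)c1ccc2[nH]c(-c3ccccc3)nc2c1` is a simple aromatic compound bearing a trifluoromethyl group on the shared core. Going by the values given here, in a functional assay on aorta (Rattus norvegicus, strain Wistar) for inhibition, with a stated time of 60 min (on this read-out lower numbers stand for smaller maximal responses and higher numbers for larger maximal responses), compound 1 gives 91.2%, the higher of the two numbers measured so far. Compound 2 `Oc1ccc(-c2nc3cc(C(F)(F)F)ccc3[nH]2)cc1` carries a hydroxy in place of hydrogen on an aromatic carbon, and compound 2 gives 51.2%, so that a number 40 percentage points lower from compound 1 to compound 2 (beyond the scatter). Compound 3 `O=[N+]([O-])c1ccccc1-c1nc2cc(C(F)(F)F)ccc2[nH]1` instead carries nitro in place of hydrogen on an aromatic carbon. Among the compounds with values here, no measured step involves a nitro group, so the hydroxy step is the only guide, and a different change need not act alike. Compound 3 is therefore expected to show a smaller maximal response, by a more modest step than the hydroxy step. For compound 3 the expected step is a number 16.2 percentage points lower from compound 1 to compound 3 (beyond the scatter). The estimate for compound 3 is 75%, between 55% and 92%.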

Compound 3, largest response reached (Emax), in percent of the reference or control that the assay uses: 93.2%
The estimate for compound 3 lay 18.2 percentage points below the measured number; the measured number lies above the stated range.
By their numbers in this assay, from the lowest: compound 2; then compounds 1 and 3 (each within the scatter of the next).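

With nitro in place of hydrogen on an aromatic carbon, ortho to a large group, the result is a number 2 percentage points higher from compound 1 to compound 3 (within the scatter) in this assay and so no real change. Unlike the hydroxy change, which gave a number 40 percentage points lower from compound 1 to compound 2 (beyond the scatter), this replacement on the six-membered aromatic ring of carbon only shows that a lower number does not follow from every added group. Nothing measured here explains this difference between the two groups. On these data alone, whether an amine or a carboxylic acid at this same place would also leave the maximal response unchanged stays open. So does what hydroxy itself would do there.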